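A Basic Side Chain Added to a Silent Core

The source may report more compounds than this note shows. Statements on the series, on what has been measured and on what is new or still open speak of the compounds shown alone.

Compound 1 `Cn1cc(C2=C(c3n[nH]c4ncccc34)C(=O)NC2=O)c2ccccc21` is the starting point. In a functional assay on A549 cells (Homo sapiens) for antiproliferative activity, read by MTT assay, with a stated time of 48 h (a lower number here means a stronger inhibitor, a higher number a weaker inhibitor), compound 1 gives only a limit, > 100000 nM, not a number. Compound 2 `Cn1cc(C2=C(c3n[nH]c4ncccc34)C(=O)N(c3cccc4ccccc34)C2=O)c2ccccc21` carries naphthalen-1-yl in place of hydrogen on an amide-type nitrogen in a ring. In this assay compound 2 likewise gives only the limit > 100000 nM. The step that the two limits leave unreadable from compound 1 to compound 2 cannot be read, as both compounds sit at the limit of > 100000 nM in this assay, at which 2 of the 3 values shown sit. Compound 3 `Cn1cc(C2=C(c3nn(CCCn4ccnc4)c4ncccc34)C(=O)N(c3ccccc3)C2=O)c2ccccc21` differs from compound 1 in two places at once, and in this assay compound 3 gives a number, 1560 nM.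

Compound 4 `CN1CCN(CCCn2nc(C3=C(c4cn(C)c5ccccc45)C(=O)NC3=O)c3cccnc32)CC1` is the new compound: 3-(4-methylpiperazin-1-yl)propyl in place of hydrogen on an aromatic nitrogen. Among the compounds with values here, no measured step matches this change alone; the only pair differing in one place, compound 1 and compound 2, alters a different position and stays unreadable. Compound 3 shows that a chain of this kind on the aromatic nitrogen can go with a measurable value of 1560 nM, though its amide-type nitrogen in the ring also carries phenyl. The step of an at least 33-fold lower number from compound 1 to compound 4 (1.52 log units; beyond the scatter) is therefore expected to leave the limit behind. Compound 4 is estimated at 3000 nM, between 800 nM and 30000 nM.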

Compound 4, half-maximal inhibitory concentration: > 100000 nM
Compound 4 ended at the assay's limit; the forecaster's own chance of this, stated with the estimate: 25%; at least 33-fold (1.52 log units) between middle value and limit.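

Compound 1 and compound 4 both give only a limit in this assay, not a number, and the step between them cannot be read: the limit of > 100000 nM in this assay, at which 3 of the 4 values shown sit.

The compounds shown leave open whether 3-(4-methylpiperazin-1-yl)propyl on the aromatic nitrogen changes the value at all in this assay.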